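The source may report more compounds than this note shows. Statements on the series, on what has been measured and on what is new or still open speak of the compounds shown alone.

Compound 2 `N#Cc1ccc(COc2nc3ccccc3s2)cc1` stands highest of the two numbers measured in a functional assay on the whole organism with Mus musculus as the target, with a stated time of 1 h, at a dose of 100 mg/kg by the intraperitoneal route; a lower number here means less inhibition, a higher number more inhibition at the dose given (going by the name of the read-out): compound 2 gives 12.7%, while compound 1 `Cc1ccc(COc2nc3ccccc3s2)cc1` gives 1.95%, with a rise of a number 10.8 percentage points higher from compound 1 to compound 2 (beyond the scatter). The change to compound 3 `COc1ccc(COc2nc3ccccc3s2)cc1` is methoxy in place of cyano on an aromatic carbon. Among the measured compounds shown here, only that one step bears on it, and only indirectly, since methoxy is neither of the groups it compares; the earlier step itself was modest. Compound 3 is therefore expected to fall between the two measured numbers, a step of a number 6.7 percentage points lower from compound 2 to compound 3 (within the scatter) being estimated, most of it within the scatter. Compound 3 is thus expected to give about 6%, with a range from 0% to 20%.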

Compound 3, a percentage reported as inhibition, in the whole organism at one dose (the size of the read-out at that dose, not a potency): 2.43%
Compound 3: the middle estimate sits 3.6 percentage points above what was measured, within the range that was stated.
By their numbers in this assay, from the lowest: compounds 1 and 3 (each within the scatter of the next); then compound 2.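

At this place, on an aromatic carbon para to a large group, methoxy in place of cyano gives a number 10.3 percentage points lower from compound 2 to compound 3 (beyond the scatter) in this assay. Methoxy in place of methyl gives a number 0.5 percentage points higher from compound 1 to compound 3 (within the scatter), so of the three groups only cyano stands apart. No measurement at hand explains this difference. The compounds shown leave open whether an amine, a carboxylic acid or chlorine at this place would match cyano or fall level with methyl and methoxy. They also leave open whether any group here could reach a much higher number than compound 2 does.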